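A few compounds are considered here, and "the series" means these few. Any claim that something is new, unique, unknown or untested is made for them only; others in the source may bear on it.

- Compound 1 `CC[C@@H]1C(=O)N(C)c2cnc(-n3ccnc3-c3ccccc3)nc2N1[C@@H]1CCOC1`: 1.8
- Compound 2 `CC[C@@H]1C(=O)N(C)c2cnc(-n3ccnc3-c3ccc(F)cc3)nc2N1[C@H]1CCOC1`: 2
- Compound 3 `CC[C@@H]1C(=O)N(C)c2cnc(-n3ccnc3-c3ccc(F)cc3)nc2N1C1COC1`: 1.6

In a physicochemical assay for lipophilicity (on this read-out higher numbers stand for higher lipophilicity and lower numbers for lower lipophilicity), compound 3 gives 1.6, within the scatter of compound 1 and beyond the scatter of compound 2. Compound 4 `CC[C@@H]1C(=O)N(C)c2cnc(-n3ccnc3-c3ccc(F)cc3)nc2N1CCC(F)(F)F` carries 3,3,3-trifluoropropyl in place of oxetan-3-yl on a nitrogen on an aromatic ring in a ring. Among the compounds with values here, the only measured step at this place is a number 0.40 log units lower from compound 2 to compound 3 (beyond the scatter), with oxetan-3-yl in place of oxolan-3-yl. No fluorinated chain has been measured here, so that step is only a loose guide to size. A larger step upward, beyond the scatter, is expected. The expected step is a number 0.80 log units higher from compound 3 to compound 4 (beyond the scatter). The estimate for compound 4 is 2.4. The expected range for compound 4 runs from 2 to 2.9.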

Compound 4, partition coefficient: 3.1
Estimate against measurement, compound 4: 0.70 log units below, outside the stated range (above it).
By their numbers in this assay, from the lowest: compounds 3, 1 and 2 (each within the scatter of the next, the first and the last beyond it); then compound 4.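

In this assay the group on this nitrogen proves able to shift the number far more than earlier compounds suggested: 3,3,3-trifluoropropyl in place of oxetan-3-yl gives a number 1.50 log units higher from compound 3 to compound 4 (beyond the scatter) and in place of oxolan-3-yl gives a number 1.10 log units higher from compound 2 to compound 4 (beyond the scatter) on the same core. Within the data shown here, the only earlier step here was a number 0.40 log units lower from compound 2 to compound 3 (beyond the scatter) and it went from one oxygen-containing ring to another, so leaving the ring for a fluorinated chain reaches much further in this assay than changing ring size did.

As far as these compounds go, whether a plain propyl chain, a longer chain or an amine at this place would give a similar number stays open, as does how the step divides between the fluorine atoms and the loss of the ring. Nothing available here explains the size of these steps.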